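A few compounds are considered here, and "the series" means these few. Any claim that something is new, unique, unknown or untested is made for them only; others in the source may bear on it.

Three compounds have been measured in a functional assay on HepG2 cells (Homo sapiens) for antiproliferative activity, read by MTT assay, with a stated time of 48 h; a higher number here means a weaker inhibitor, a lower number a stronger inhibitor:

Compound 1 `Cc1ccc(NC(=O)Nc2cccc(CNc3nccnc3Cl)c2)cc1`: 11500 nM
Compound 2 `CCOc1ccc(NC(=O)Nc2cccc(CNc3nccnc3Cl)c2)cc1`: 7050 nM
Compound 3 `O=C(Nc1cccc(CNc2nccnc2Cl)c1)Nc1ccc(F)c(Cl)c1`: 6750 nM

Compound 2 gives the second highest of these three numbers. Its nearest neighbour is compound 3, with a 1.0-fold lower number from compound 2 to compound 3 (0.02 log units; within the scatter), and its furthest is compound 1, with a 1.6-fold lower number from compound 1 to compound 2 (0.21 log units; within the scatter); all three compounds therefore sit within the scatter of one another, and none can be called stronger or weaker.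

Compound 4 `COc1ccccc1NC(=O)Nc1cccc(CNc2nccnc2Cl)c1` differs from compound 2 in one place: 2-methoxyphenyl in place of 4-ethoxyphenyl on an amide-type nitrogen.

Two measured steps also swap the group on the amide-type nitrogen: a 1.7-fold lower number from compound 1 to compound 3 (0.23 log units; within the scatter) and a 1.0-fold lower number from compound 2 to compound 3 (0.02 log units; within the scatter), both within the scatter. The third, a 1.6-fold lower number from compound 1 to compound 2 (0.21 log units; within the scatter), is also within the scatter. Going by the values given here, no measured step swaps a 4-substituted ring for a 2-substituted one, so that part of the change is untested. On this evidence the expected step is a 1.1-fold higher number from compound 2 to compound 4 (0.05 log units; within the scatter), that is none beyond the scatter.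

Compound 4 is therefore estimated at 8000 nM, in the range 3500 nM to 18000 nM.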

Compound 4, half-maximal inhibitory concentration: 13700 nM
The estimate for compound 4 lay 1.7-fold (0.23 log units) below the measured number, within the range that was stated.
By their numbers in this assay, from the lowest: compounds 3, 2, 1 and 4 (each within the scatter of the next, the first and the last beyond it).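

In this assay, going by these compounds alone, 2-methoxyphenyl on the amide-type nitrogen gives the first step at this position to pass the scatter, and only modestly, with a 2.0-fold higher number from compound 3 to compound 4 (0.31 log units; beyond the scatter) as its size. The other two steps stay within the scatter, a 1.9-fold higher number from compound 2 to compound 4 (0.29 log units; within the scatter) and a 1.2-fold higher number from compound 1 to compound 4 (0.08 log units; within the scatter), so compound 4 separates only from compound 3 and cannot be told apart from compound 1 or compound 2, which carry 4-substituted rings. Nothing available explains why compound 4 separates from compound 3.

Compound 4 differs from compound 2 in both the place and the length of its ether group, and a 4-methoxyphenyl or 2-ethoxyphenyl group would be needed to tell those two changes apart. From the compounds shown here alone, how a ring carrying an amine or a carboxylic acid would behave at this nitrogen also remains open.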